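The compounds below may be only part of what the source reports. "The series", "measured", "known", "first", "only" and "open" are said of these compounds alone.

Three esters of one shared core, each bearing a substituted five-membered ring with three nitrogen atoms, have been examined in a functional assay on A549 cells (Homo sapiens) for antiproliferative activity, read by MTT assay, with a stated time of 48 h; on this read-out lower numbers stand for stronger inhibition and higher numbers for weaker inhibition. Compound 1 `C/C(=C\CC/C(C)=C/CC[C@@H]1[C@@]2(C)CCC(=O)C(C)(C)[C@H]2CC[C@@]1(C)O)CC/C=C(\C)C(=O)OCc1cn(-c2ccc(Br)cc2)nn1` reaches only the limit of this assay and gives > 150000 nM. Among the measured compounds shown here, compound 2 `C/C(=C\CC/C(C)=C/CC[C@@H]1[C@@]2(C)CCC(=O)C(C)(C)[C@H]2CC[C@@]1(C)O)CC/C=C(\C)C(=O)OCc1cn([C@@H]2C[C@@H](n3cc(C)c(=O)[nH]c3=O)O[C@H]2CO)nn1` is the one member with a number in this assay and gives 35000 nM. Compound 3 `C/C(=C\CC/C(C)=C/CC[C@@H]1[C@@]2(C)CCC(=O)C(C)(C)[C@H]2CC[C@@]1(C)O)CC/C=C(\C)C(=O)OCc1cn(-c2cccc(C)c2)nn1` again reaches only a limit in this assay and gives > 150000 nM. The step that the two limits leave unreadable from compound 1 to compound 3 is therefore unreadable, since both ends are limits. Compound 1 thus stands at the top edge of what has been recorded, (the limit of > 150000 nM in this assay, at which 2 of the 3 values shown sit).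

Compound 4 `C/C(=C\CC/C(C)=C/CC[C@@H]1[C@@]2(C)CCC(=O)C(C)(C)[C@H]2CC[C@@]1(C)O)CC/C=C(\C)C(=O)OCc1cn(-c2cccc(Br)c2)nn1` is the positional isomer of compound 1, differing by 3-bromophenyl in place of 4-bromophenyl on an aromatic nitrogen. For the measured compounds named here, the only measured step at this position, a step that the two limits leave unreadable from compound 1 to compound 3, gives no readable size, so no direction can be drawn from it, and compound 2 carries a quite different group there. The evidence on the measured compounds is simply that both compound 1 and compound 3 sit at the limit.

On that basis compound 4 is expected to sit near the limit as well, with an estimated value of about 150000 nM and a likely range from 40000 nM to 400000 nM. That expectation corresponds to an estimated step of a number no higher from compound 1 to compound 4 (the limit leaves the size open), no change beyond the scatter.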

Compound 4, half-maximal inhibitory concentration: > 150000 nM
Compound 4: only a limit was reported; the forecaster's own chance of this, stated with the estimate: 75%; the middle value lies on the limit itself.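

Compound 4 also gives a limit in this assay, > 150000 nM, so no step can be read from compound 4 to either compound 1 or compound 3, where both ends are limits. The compounds shown leave open how far any of these three aryl esters lies past that limit: the limit of > 150000 nM in this assay, at which 3 of the 4 values shown sit.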